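A few compounds are considered here, and "the series" means these few. Any claim that something is new, unique, unknown or untested is made for them only; others in the source may bear on it.

Compound 2 `CCc1cc2ccccc2nc1-c1cc(-c2ccc(C(F)(F)F)cc2)no1` was tested in a functional assay on PC-3 cells (Homo sapiens) for inhibition, read by MTT assay, with a stated time of 24 h; a lower number here means a stronger inhibitor, a higher number a weaker inhibitor. In this assay compound 2 gives > 100000 nM, which is a limit of the assay rather than a measured number. Compound 1 `CCCc1cc2ccccc2nc1-c1cc(-c2ccc(C)cc2)no1`, which carries a different substituent on its outer ring, was tested in this assay as well. In this assay compound 1 gives > 100000 nM, again a limit and not a number. Both values shown so far therefore sit at the same place: the limit of > 100000 nM in this assay, at which 2 of the 2 values shown sit.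

Compound 3 `CCCc1cc2ccccc2nc1-c1cc(-c2ccc(C(F)(F)F)cc2)no1` has not yet been measured. It differs from compound 2 in one way: methyl in place of hydrogen on a saturated chain carbon, two bonds along the chain from an aromatic carbon, so the ethyl chain of compound 2 becomes a propyl chain. Going by the values given here, no measured pair in this set shows what such a change does here. Among the compounds with values here, the only guide is compound 1, which already carries the propyl chain, and in this assay compound 1 gives > 100000 nM, a limit. The step from compound 2 to compound 3 is therefore expected to be none beyond the scatter, a number no higher from compound 2 to compound 3 (the limit leaves the size open). Compound 3 is expected to give about 100000 nM in this assay, most likely reported once more as a limit, within a range from 30000 nM to 300000 nM.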

Compound 3, half-maximal inhibitory concentration: 33800 nM
For compound 3 the middle estimate is 3.0-fold (0.47 log units) above the measured one; low and high end bracket the measured number.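

In this assay, methyl in place of hydrogen on a saturated chain carbon, two bonds along the chain from an aromatic carbon, turns the ethyl chain into a propyl chain and gives an at least 2.9-fold lower number from compound 2 to compound 3 (0.47 log units; beyond the scatter), the first sign that this chain position affects the result. Trifluoromethyl in place of methyl on an aromatic carbon gives an at least 2.9-fold lower number from compound 1 to compound 3 (0.47 log units; beyond the scatter), so with the propyl chain present, the group on that aromatic carbon matters too. Of the three compounds, only compound 3 combines the propyl chain with trifluoromethyl and gives a measured number, while compound 1 and compound 2 each have only one of these features and give limits of the assay rather than numbers: the limit of > 100000 nM in this assay, at which 2 of the 3 values shown sit.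

On these data alone, both steps start from a limit, so each shows only a smallest possible size, and the full effect of either change remains open. As far as these compounds go, it is also open whether a longer chain such as butyl would lower the number further, and whether a nitrile or a chlorine atom in place of trifluoromethyl would serve as well.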